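Moving the fluorine on the benzyl ether of compound 3

The source may hold more compounds than are shown below. What is called first, only, known or untested is meant among the compounds shown, and "the series" means these compounds.

Of the compounds shown here, three have so far been measured in a functional assay on SW-620 cells (Homo sapiens) for inhibition, read by MTT assay, with a stated time of 48 h; a lower number here means a stronger inhibitor, a higher number a weaker inhibitor. Compound 1 `Cc1ccc(NC(=S)NC(=O)c2ccc(OCc3ccccc3Cl)cc2)cc1-c1nc2ccccc2[nH]1` gives 57100 nM, compound 2 `Cc1ccc(NC(=O)NC(=O)c2ccc(OCc3ccccc3F)cc2)cc1-c1nc2ccccc2[nH]1` gives 4110 nM, and compound 3 `O=C(NC(=O)c1ccc(OCc2ccccc2F)cc1)Nc1ccc(Cl)c(-c2nc3ccccc3[nH]2)c1` gives 2930 nM. Compound 3 carries the lowest number of the three, but its distance to compound 2 lies within the scatter, so these two cannot be told apart; compound 1 stands well above both. For the measured compounds named here, the only measured pair that differs in a single place is a 1.4-fold lower number from compound 2 to compound 3 (0.15 log units; within the scatter), and that change concerns a chloro in place of methyl on an aromatic carbon, not the (2-fluorobenzyl)oxy group.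

Compound 4 `O=C(NC(=O)c1ccc(OCc2ccc(F)cc2)cc1)Nc1ccc(Cl)c(-c2nc3ccccc3[nH]2)c1` keeps the whole of compound 3 and shifts only the fluorine: 4-fluorophenyl in place of 2-fluorophenyl on a saturated chain carbon bound to an oxygen on an aromatic ring. Going by the values given here, no measured pair shows a change of this kind, and the one measured step does not touch this part of the molecule, so the data give no direction for the move. In this assay the expected step is a 1.0-fold higher number from compound 3 to compound 4 (0.01 log units; within the scatter), which is nothing beyond the scatter. Compound 4 is therefore estimated at 3000 nM, with a likely range from 1000 nM to 9000 nM.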

Compound 4, half-maximal inhibitory concentration: 33600 nM
Beside the measured number, compound 4's estimate is 11-fold (1.05 log units) below it; the whole stated range lies below it.
By their numbers in this assay, from the lowest: compounds 3 and 2 (each within the scatter of the next); then compounds 4 and 1 (each within the scatter of the next).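

In this assay the place of the fluorine on the benzyl ether matters: going from 2-fluorophenyl to 4-fluorophenyl gives a large step towards weaker inhibition (an 11-fold higher number from compound 3 to compound 4 (1.06 log units; beyond the scatter)), even though the group that leaves and the group that enters have exactly the same atoms. For the compounds shown here, the earlier compounds could not show this, since their only single-place step concerned a different part of the molecule and stayed within the scatter (a 1.4-fold lower number from compound 2 to compound 3 (0.15 log units; within the scatter)), so this is the first sign that the numbers respond to a change at this position, on a saturated chain carbon bound to an oxygen on an aromatic ring. Nothing measured in this set explains why the shift has so large an effect.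

The compounds shown leave open how a plain benzyl group with no halogen, or a longer chain such as phenylethyl, would compare with the (2-fluorobenzyl)oxy group of compound 3. They also leave open whether the same shift of fluorine would have a similar effect with the methyl of compound 2 in place of the chloro.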